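The source may hold more compounds than are shown below. What is called first, only, known or untested is meant among the compounds shown, and "the series" means these compounds.

Measured compounds:
- compound 1 `C=CCn1c(=O)/c(=C\c2cc(Br)ccc2F)[nH]c(=O)/c1=C\c1ccccc1OC`: 34600 nM
- compound 2 `COc1ccccc1/C=c1\c(=O)[nH]/c(=C/c2cccc(Cl)c2Cl)c(=O)n1C`: 200 nM
- compound 3 `C=CCn1c(=O)/c(=C\c2ccc(Cl)c(Cl)c2)[nH]c(=O)/c1=C\c1ccccc1`: "not active" (no number reported), no number reported

In a functional assay on HeLa cells (Homo sapiens) for cytotoxicity, read by CCK-8 assay, with a stated time of 72 h (a higher number here means a weaker inhibitor, a lower number a stronger inhibitor), compound 1 gives 34600 nM, the highest of the two numbers on hand. Compound 2 gives 200 nM in this assay, a far lower number, well beyond the scatter; compound 2 differs from compound 1 in several places at once, so no single change can be read from that gap. Compound 3 is reported as not active in this assay without a number.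

Compound 4 `C=CCn1c(=O)/c(=C\c2cccc(C)c2)[nH]c(=O)/c1=C\c1ccccc1OC` is not yet measured. It differs from compound 1 by 3-methylphenyl in place of 5-bromo-2-fluorophenyl on a double-bonded chain carbon bound to an aromatic carbon. Going by the values given here, no step between measured compounds isolates this change, and the shared core with the allyl chain carries only one numbered value, that of compound 1. The expectation is therefore anchored on compound 1, with wide bounds. The step from compound 1 to compound 4 is estimated at a 1.2-fold higher number from compound 1 to compound 4 (0.06 log units; within the scatter), that is, no move beyond the scatter in either direction, because compound 1 as the only comparable anchor gives 34600 nM. Compound 4 is expected to give about 40000 nM in this assay, within a range of 8000 nM to 200000 nM, with a real chance that only an inactive call is returned.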

Compound 4, half-maximal inhibitory concentration: 19300 nM
Estimate against measurement, compound 4: 2.1-fold (0.32 log units) above; the range from low to high includes it.
By their numbers in this assay, from the lowest: compound 2; then compounds 4 and 1 (each within the scatter of the next).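

In this assay, going by these compounds alone, 3-methylphenyl in place of 5-bromo-2-fluorophenyl on a double-bonded chain carbon bound to an aromatic carbon gives a 1.8-fold lower number from compound 1 to compound 4 (0.25 log units; within the scatter), the first step that isolates a single place, and it lies within the scatter. For this pair, the bromine and the fluorine can both leave and a methyl-bearing ring can take their place with no move beyond the scatter, so neither halogen is shown to be needed on this ring with the allyl chain and the rest of the core held constant. No measurement at hand bears on why this exchange leaves the reading within the scatter.

As far as these compounds go, whether an amine or a carboxylic acid on this aromatic ring would move the number beyond the scatter stays open, since this single pair covers only the two groups exchanged. Compound 2 gives 200 nM but differs from compound 1 and from compound 4 in several places at once, so the steps to it cannot be read, and the part played by the allyl chain, or by a longer chain in its place, remains unresolved.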